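The source may hold more compounds than are shown below. What is called first, only, known or untested is meant among the compounds shown, and "the series" means these compounds.

Measured compounds:
Compound 1 `CCC1(CCCCN2CCN(c3ccc(Cl)cc3)CC2)C(=O)Nc2ccccc21` gives 10 mg/kg.
Compound 2 `CCC1(CCCCN2CCN(c3cccc(Cl)c3)CC2)C(=O)Nc2cc(F)c(Cl)cc21` gives 20 mg/kg.
Compound 3 `CCC1(CCCCN2CCN(c3cccc(Cl)c3)CC2)C(=O)Nc2ccc(Cl)cc21` gives only a limit of the assay, > 20 mg/kg.

These values come from a functional assay on the whole organism (strain Wistar) with Rattus norvegicus as the target, with a stated time of 5 min; on this read-out lower numbers stand for an effect already at smaller amounts and higher numbers for an effect only at larger amounts of compound. Compound 1 and compound 2 have the two plain numbers, and the gap between them lies within the usual scatter, so neither can be called better than the other. Within the data shown here, the single step measured between compounds that differ in one place is a number no lower from compound 2 to compound 3 (the limit leaves the size open), and its size cannot be read because of the limit of > 20 mg/kg in this assay, at which 1 of the 3 values shown sits.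

Compound 4 `CCC1(CCCCN2CCN(c3ccc(Cl)c(Cl)c3)CC2)C(=O)Nc2ccccc21` is not yet measured. It differs from compound 1 by chloro in place of hydrogen on an aromatic carbon. Among the measured compounds shown here, no measured step changes the same place on the same ring, and the one step that was measured, from compound 2 to compound 3, concerns a different ring and a different group and gives no readable size. There is thus no basis for expecting a move beyond the scatter. In this assay compound 4 is therefore expected to give about 10 mg/kg, between 5 mg/kg and 20 mg/kg. The step expected is no change at the digits printed from compound 1 to compound 4 (within the scatter), which means no change beyond the scatter is estimated.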

Compound 4, minimum effective dose: > 20 mg/kg
Compound 4: only a limit was reported; the forecaster's own chance of this, stated with the estimate: 25%; at least 2.0-fold (0.30 log units) between middle value and limit.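

In this assay, going from the 4-chlorophenyl group to the 3,4-dichlorophenyl group comes with an at least 2.0-fold higher number from compound 1 to compound 4 (0.30 log units; that floor lies within the scatter). This is the first step shown on this chlorine-bearing aromatic ring, at a place ortho to a chloro group and meta to a large group, whereas the earlier step concerned a fluoro group on the other aromatic ring of the compounds. The result for compound 4 is a limit of the assay and not a plain number, so the smallest step it allows stays inside the scatter while the true step could be much larger, and the size stays unknown because the read-out stops at this limit: the limit of > 20 mg/kg in this assay, at which 2 of the 4 values shown sit.

The compounds shown leave open whether the loss of a readable effect belongs to chloro in particular or would also follow from a smaller or different group at this place, such as fluoro, methyl or methoxy. They also leave open whether an amine or a hydroxyl group here would give a plain number that could be compared directly with compound 1.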